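Replacing a Basic Ring with a Dihydroxypropyl Chain

A few compounds are considered here, and "the series" means these few. Any claim that something is new, unique, unknown or untested is made for them only; others in the source may bear on it.

Compound 1, `COc1cc(OC)c2c(=O)cc(-c3ccc(OCCBr)cc3)oc2c1`: 20%
Compound 2, `COc1cc(OC)c2c(=O)cc(-c3ccc(OC4CCN(C)CC4)cc3)oc2c1`: "not determined" (no result reported)
Compound 3, `COc1cc(OC)c2c(=O)cc(-c3ccc(OCCCN)cc3)oc2c1`: "not determined" (no result reported)

Three compounds share a common core and differ only in the group carried on the oxygen of the pendant aromatic ring. In a functional assay (Homo sapiens) for antiproliferative activity, read by resazurin assay, with a stated time of 48 h, tested at 20 uM (on this read-out higher numbers stand for a stronger effect at the one concentration tested and lower numbers for a weaker effect), compound 1 gives 20%. For compound 2 the outcome is "not determined" (no result reported), so compound 2 stands without any single number on which to place it; compound 3 is in the same situation, with "not determined" (no result reported). Among the measured compounds shown here, with only one numerical result in the set, no step between measured compounds can be drawn, and compound 1 offers the sole point of reference.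

The account now follows the move from compound 2 to compound 4, `COc1cc(OC)c2c(=O)cc(-c3ccc(OCC(O)CO)cc3)oc2c1`, the compound still to be measured. The change is 2,3-dihydroxypropyl in place of 1-methylpiperidin-4-yl on an oxygen on an aromatic ring. Because compound 2 has no value in this assay, the size and direction of this step cannot be computed from data, and the expectation rests on compound 1 alone. Given that compound 1 gives 20%, a read-out for compound 4 of a similar or somewhat smaller size is expected, with the gap between them likely staying within the scatter. Compound 4 is therefore estimated at 15% in this assay, within a range from 0% to 35%.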

Compound 4, a percentage reported as inhibition, at one concentration (the size of the read-out at that concentration, not a potency): 16%
Compound 4: the middle estimate sits 1 percentage points below what was measured; the range from low to high includes it.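

Compound 4 gives this position a second number in this assay, and the step reads a number 4 percentage points lower from compound 1 to compound 4 (within the scatter), so on this read-out a 2,3-dihydroxypropyl group on the oxygen on the aromatic ring cannot be told apart from the bromine-bearing chain of compound 1. On these data alone, the steps that would link compound 4 to the 1-methylpiperidin-4-yl group of compound 2 or to the amine-bearing chain of compound 3 cannot be read, as neither of those compounds has a number, so what the change from the ring to the 2,3-dihydroxypropyl chain does in this assay remains unknown. No measurement is at hand that bears on this result.

The compounds shown leave open whether a carboxylic acid or a longer chain ending in a hydroxyl group on the same oxygen would give a read-out beyond the scatter of compound 1 and compound 4. They also leave open how a morpholine ring at this place would compare with the 2,3-dihydroxypropyl group of compound 4 in this assay.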